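Side-chain isomers: from compound 3 to compound 4

This account rests on a few compounds, and the source may have more. Where it says the series, first, only, none or still open, it means among the compounds named here.

- compound 1 `CC(C)CN(C1=NCCN1)c1c(Br)cccc1Br` gives -0.64 in a physicochemical assay for lipophilicity; on this read-out lower numbers stand for lower lipophilicity and higher numbers for higher lipophilicity
- compound 2 `CC(C)CCN(C1=NCCN1)c1c(Br)cccc1Br` gives 0.16 in this assay
- compound 3 `C=C(C)CN(C1=NCCN1)c1c(Br)cccc1Br` gives -0.66 in this assay

Compound 3 sits level with compound 1 at the low end of the three, while compound 2 stands clear of both, with a number 0.82 log units lower from compound 2 to compound 3 (beyond the scatter) as the measured gap. Compound 4 `C=CCCN(C1=NCCN1)c1c(Br)cccc1Br` differs by allyl in place of 1-methylethenyl on a saturated chain carbon bound to a nitrogen on an aromatic ring with the same atoms joined differently. Within the data shown here, the closest precedent is a number 0.02 log units lower from compound 1 to compound 3 (within the scatter) as a change in the chain that left the number in place. The larger precedent is a number 0.80 log units higher from compound 1 to compound 2 (beyond the scatter) and shows that chain changes here can also move it upward. A small upward move is expected in this assay and most likely none beyond the scatter, with a number 0.26 log units higher from compound 3 to compound 4 (within the scatter) as the expected step. Compound 4 is estimated at -0.4 with an expected range from -0.8 to 0 for now.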

Compound 4, distribution coefficient: -0.63
Estimate against measurement, compound 4: 0.23 log units above; low and high end bracket the measured number.
By their numbers in this assay, from the lowest: compounds 3, 1 and 4 (each within the scatter of the next); then compound 2.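

With the same atoms joined differently, allyl in place of 1-methylethenyl gives a number 0.03 log units higher from compound 3 to compound 4 (within the scatter) in this assay at this position, so shifting the branch and the double bond leaves the number in place. Allyl in place of isopropyl gives a number 0.01 log units higher from compound 1 to compound 4 (within the scatter) in this comparison, while vinyl in place of isopropyl gives a number 0.79 log units lower from compound 2 to compound 4 (beyond the scatter) and leaves compound 2 alone set apart from the other three.

From the compounds shown here alone, whether a hydroxyl or an amine on this chain would leave the number in place stays open. Nothing at hand accounts for these readings.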